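A few compounds are considered here, and "the series" means these few. Any claim that something is new, unique, unknown or untested is made for them only; others in the source may bear on it.

In a functional assay on MOLT-4 cells (Homo sapiens) for inhibition, read by MTT assay, with a stated time of 72 h (a higher number here means a weaker inhibitor, a lower number a stronger inhibitor), compound 1 (`COc1cc(NC(C)CCCNC(=O)Nc2ccc(Br)cc2)c2ncccc2c1`) gives 25000 nM. Compound 3 (`COc1cc(NC(C)CCCNC(=O)NNC(=O)Nc2ccc(C(F)(F)F)cc2)c2ncccc2c1`) gives 24000 nM, which lies within the scatter of compound 1. Compound 2 (`COc1cc(NC(C)CCCNC(=O)NNC(=O)Nc2ccc(Cl)cc2)c2ncccc2c1`) gives 186000 nM, the highest number of the three and so the weakest inhibitor.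

Compound 4 (`COc1cc(NC(C)CCCNC(=O)NNC(=O)Nc2cccc(F)c2)c2ncccc2c1`) has not yet been measured. It differs from compound 1 as follows: ((3-fluorophenyl)carbamoyl)amino in place of 4-bromophenyl on an amide-type nitrogen. In words, ((3-fluorophenyl)carbamoyl)amino stands in place of 4-bromophenyl on an amide-type nitrogen.

For the measured compounds named here, two measured steps bear on this change. A closely similar swap, with a 4-chlorophenyl end, gave a 7.4-fold higher number from compound 1 to compound 2 (0.87 log units; beyond the scatter). Trifluoromethyl in place of chloro on an aromatic carbon then gave a 7.8-fold lower number from compound 2 to compound 3 (0.89 log units; beyond the scatter), which returned the number to the level of compound 1. The longer group therefore does not always raise the number, and compound 3 goes against that reading. Going by the values given here, no measured compound carries a 3-fluorophenyl end, so compound 4 could land near either value.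

In this assay, a moderate step to a higher number is expected, estimated as a 2.6-fold higher number from compound 1 to compound 4 (0.41 log units; beyond the scatter). For compound 4 the estimated value is 65000 nM, with an expected range of 20000 nM to 190000 nM.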

Compound 4, half-maximal inhibitory concentration: >= 250000 nM
Compound 4: no number, only a limit; the forecaster's own chance of this, stated with the estimate: 10%; middle value at least 3.8-fold (0.58 log units) away from the limit.
By their numbers in this assay, from the lowest: compounds 3 and 1 (each within the scatter of the next); then compound 2. At a limit, above all of these: compound 4.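

In this assay, compound 4 reads only as a limit, not as a number: the limit of >= 250000 nM in this assay, at which 1 of the 4 values shown sits.

Placing ((3-fluorophenyl)carbamoyl)amino in place of 4-bromophenyl on the amide-type nitrogen gives an at least 10-fold higher number from compound 1 to compound 4 (1.00 log units; beyond the scatter), and 3-fluorophenyl in place of 4-(trifluoromethyl)phenyl on the amide-type nitrogen gives an at least 10-fold higher number from compound 3 to compound 4 (1.01 log units; beyond the scatter). The longer group therefore does not fix the number by itself: the end ring it carries separates compound 3 from compound 4, and compound 3 is the exception among the longer-group compounds, staying within the scatter of compound 1.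

3-Fluorophenyl in place of 4-chlorophenyl on the amide-type nitrogen gives an at least 1.3-fold higher number from compound 2 to compound 4 (0.12 log units; that floor lies within the scatter), so the order of those two stays unknown. The 3-fluorophenyl and 4-(trifluoromethyl)phenyl ends differ in both group and ring place, so a 4-fluorophenyl or 3-(trifluoromethyl)phenyl end would be needed to tell these two apart.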